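Replacing morpholin-4-yl with 3-(dimethylamino)pyrrolidin-1-yl in compound 3

The compounds below may be only part of what the source reports. "The series", "measured", "known", "first", "only" and "open" are said of these compounds alone.

Three compounds have been measured so far in an ADME assay on microsomes from liver (Mus musculus) for metabolic stability, read by mass spectrometry, with a stated time of 40 min, tested at 1 uM (on this read-out lower numbers stand for a less stable compound and higher numbers for a more stable compound), with these results
- compound 1 `COc1cc(N2CCN(C(=O)C3CCC(O)CC3)CC2)ccc1Nc1nc(NC2CCCCC2)c2nc[nH]c2n1` gives 68%
- compound 2 `COc1cc(N2CCN(CC3CCOC3)CC2)ccc1Nc1nc(NC2CCCCC2)c2nc[nH]c2n1` gives 59%
- compound 3 `COc1cc(N2CCC(CC(=O)N3CCOCC3)CC2)ccc1Nc1nc(NC2CCCCC2)c2nc[nH]c2n1` gives 61%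

Compound 3 (at 61%) lies within the usual scatter of both compound 2 and compound 1, so no order can be read among the three. Compound 4 `COc1cc(N2CCC(CC(=O)N3CCC(N(C)C)C3)CC2)ccc1Nc1nc(NC2CCCCC2)c2nc[nH]c2n1` differs from compound 3 in one group on a carbonyl carbon, where 3-(dimethylamino)pyrrolidin-1-yl stands in place of morpholin-4-yl (3-(dimethylamino)pyrrolidin-1-yl in place of morpholin-4-yl on a carbonyl carbon). For the measured compounds named here, the only measured step is a number 9 percentage points lower from compound 1 to compound 2 (within the scatter) and it is a replacement on an amine nitrogen in a ring, so it bears on this change only loosely. Going by the values given here, no measured pair covers the departure of morpholin-4-yl, which leaves the expectation wide. In this assay the expected step is a number 5 percentage points lower from compound 3 to compound 4 (within the scatter) and this is estimated to stay within the scatter. Compound 4 is estimated at 56% with an expected range from 40% to 72% in this read-out.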

Compound 4, percent of the compound remaining: 48%
Compound 4: middle estimate off by 8 percentage points, on the high side; the range from low to high includes it.
By their numbers in this assay, from the lowest: compound 4; then compounds 2, 3 and 1 (each within the scatter of the next).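

In this assay, for the compounds shown here, the group on the carbonyl carbon proves able to move this read-out: 3-(dimethylamino)pyrrolidin-1-yl in place of morpholin-4-yl gives a number 13 percentage points lower from compound 3 to compound 4 (beyond the scatter), whereas the only earlier step stayed within the scatter. This single pair exchanges a six-membered ring holding oxygen for a five-membered ring carrying a dimethylamino group, so the ring change and the added amine are not separated. Nothing available gives a reason for this step.

As far as these compounds go, it remains open whether the step follows the dimethylamino group or the five-membered ring, a question that a plain pyrrolidin-1-yl or a 4-methylpiperazin-1-yl on the same carbonyl carbon could address. From the compounds shown here alone, it also remains open whether the same exchange gives a step of this size in other compounds, since it is read in this one pair alone.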